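The source may hold more compounds than are shown below. What is called first, only, known or untested is meant among the compounds shown, and "the series" means these compounds.

Compound 1 `COc1ccc2nc(C)cc(OCC(=O)Nc3cc(C)ccc3C)c2c1`: in a toxicity assay on HepG2 cells (Homo sapiens) for inhibition, read by CellTiter-Glo, with a stated time of 48 h (a lower number here means a stronger inhibitor, a higher number a weaker inhibitor), compound 1 gives > 100000 nM, which is a limit of the assay rather than a number.
Compound 2 `COc1ccc2nc(C)cc(OCC(=O)Nc3ccc(Cl)cc3Cl)c2c1`: in this assay compound 2 gives > 100000 nM, again a limit of the assay.
Compound 3 `COc1ccc2nc(C)cc(OCC(=O)Nc3ccc(F)cc3)c2c1`: in this assay compound 3 gives 63100 nM.

Going by the values given here, compound 3 therefore holds the only number among the three values; the other two sit at the limit of > 100000 nM in this assay, at which 2 of the 3 values shown sit. The steps that reach compound 3 are an at least 1.5-fold lower number from compound 1 to compound 3 (0.19 log units; that floor lies within the scatter) and an at least 1.5-fold lower number from compound 2 to compound 3 (0.19 log units; that floor lies within the scatter), each a floor that lies within the scatter, while a step that the two limits leave unreadable from compound 1 to compound 2 cannot be read between two limits. All three compounds share one core and differ only in the group on the amide-type nitrogen.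

Compound 4 `COc1ccc2nc(C)cc(OCC(=O)Nc3noc(C)c3C)c2c1` carries the change (4,5-dimethyl-1,2-oxazol-3-yl in place of 4-fluorophenyl on an amide-type nitrogen). Among the compounds with values here, no measured step involves an aromatic ring with hetero atoms at this place, so the measured steps give no direction for it; they show only that changes of the aryl group on the amide-type nitrogen moved the number little, if at all. Compound 4 is therefore expected to give 90000 nM in this assay, within 30000 nM to 250000 nM, which means an expected step of a 1.4-fold higher number from compound 3 to compound 4 (0.15 log units; within the scatter), with a real chance that only a limit is reported.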

Compound 4, half-maximal inhibitory concentration: > 100000 nM
Compound 4: no number, only a limit; the forecaster's own chance of this, stated with the estimate: 50%; at least 1.1-fold (0.04 log units) between middle value and limit.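

Replacing 4-fluorophenyl with 4,5-dimethyl-1,2-oxazol-3-yl brings an aromatic ring with hetero atoms onto the amide-type nitrogen for the only time in this set, and in this assay the change gives an at least 1.5-fold higher number from compound 3 to compound 4 (0.19 log units; that floor lies within the scatter). The steps from compound 1 and from compound 2 to compound 4 join two limits and cannot be read. Compound 4 thus joins the compounds without a number, leaving compound 3 as the only one with a measured value, and the series now rests mostly on a limit of the assay: the limit of > 100000 nM in this assay, at which 3 of the 4 values shown sit.

As far as these compounds go, how far compound 1, compound 2 and compound 4 lie beyond that limit remains open, so no order can be given among them. Also open, from the compounds shown here alone, is whether a pyridyl ring, an aminoethyl chain or a carboxylic acid on the amide-type nitrogen would move the number clearly away from that of compound 3.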